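Chain lengthening on a purine-like core, tested in heart mitochondria

A few compounds are considered here, and "the series" means these few. Any claim that something is new, unique, unknown or untested is made for them only; others in the source may bear on it.

Compound 1 `CCCCCCCCn1c(=O)[nH]c(=O)c2[nH]c(O)nc21` carries an octyl chain on a ring nitrogen of its core. In a functional assay (mitochondria, heart) with Bos taurus as the target (a lower number here means a stronger inhibitor, a higher number a weaker inhibitor), compound 1 gives 28000 nM. Compound 2 `CCCCCCCCCCCCn1c(=O)[nH]c(=O)c2[nH]c(O)nc21` keeps the same core but the chain is longer: the difference is butyl in place of hydrogen on a saturated chain carbon, eight bonds along the chain from an aromatic nitrogen. In this assay compound 2 gives 1600 nM, which is an 18-fold lower number from compound 1 to compound 2 (1.24 log units; beyond the scatter).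

Compound 3 `CCCCCCCCCCCCn1c(O)nc2c(=O)[nH]c(=O)[nH]c21` has a different core; the difference between the core of compound 1 and the core of compound 3 is not broken down here. In this assay compound 3 gives 1000 nM, a number that lies within the usual scatter of the number for compound 2.

Compound 4 `CCCCCCCCCCCCCCCCn1c(O)nc2c(=O)[nH]c(=O)[nH]c21` has not yet been measured. It differs from compound 3 by butyl in place of hydrogen on a saturated chain carbon, ten or more bonds along the chain from an aromatic nitrogen. Going by the values given here, this is the same kind of change as the one from compound 1 to compound 2, but not the same: the place of the butyl along the chain is not the same, as the two differences just described show, and the core is another one.

Among the compounds with values here, because the step of an 18-fold lower number from compound 1 to compound 2 (1.24 log units; beyond the scatter) was large, a lower number is expected for compound 4 as well, though only one such step is known and it sits on a different core and a shorter chain, so a smaller step is expected: a 2.5-fold lower number from compound 3 to compound 4 (0.40 log units; beyond the scatter). In this assay compound 4 is estimated to give 400 nM, likely between 100 nM and 1500 nM.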

Compound 4, half-maximal inhibitory concentration: 750 nM
The estimate for compound 4 lay 1.9-fold (0.27 log units) below the measured number; the range from low to high includes it.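

In this assay, butyl in place of hydrogen on a saturated chain carbon, ten or more bonds along the chain from an aromatic nitrogen, gives a 1.3-fold lower number from compound 3 to compound 4 (0.12 log units; within the scatter), so this step does not separate the two compounds. Set beside the earlier step, it shows that the size of this change does not carry over from one core to the other in this series: the same change on two cores in this assay, an 18-fold lower number (1.24 log units; beyond the scatter) from compound 1 to compound 2 and a 1.3-fold lower number (0.12 log units; within the scatter) from compound 3 to compound 4, 13-fold (1.12 log units) apart, beyond the scatter of two such steps

This does not show that the core is what sets the size of the step, since the two steps differ in the core and also in the place on the chain where the butyl enters, and the compounds shown do not pull these two differences apart; with only one step on each core, no general rule follows either.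

On these data alone, it remains open how the core of compound 1 and the core of compound 3 compare when each carries the same shorter chain, and whether a still longer chain on the core of compound 3 would give a step beyond the scatter. Also open, as far as these compounds go, is how either core would respond to a chain ending in an amine or a carboxylic acid.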